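The compounds below may be only part of what the source reports. "The series", "measured", "known", "first", "only" and "open" are said of these compounds alone.

Measured compounds:
Compound 1, `CCCCCCCCCCCCCCCCc1nc(N2CCC2)c(C)c(C)c1O`, gives 82% in a functional assay on cells (Lymphocyte, Homo sapiens), read by trypan blue exclusion, with a stated time of 16 h, tested at 0.5 uM; on this read-out lower numbers stand for a weaker effect and higher numbers for a stronger effect at the one concentration tested.
Compound 2, `CCCCCCCCCCCCCCCCc1c(C)c(N2CCC2)nc(C)c1O`, gives 95% in this assay.

Of the two compounds measured, compound 1 stands lowest. For the measured compounds named here, its only neighbour, compound 2, lies higher by a difference that is beyond the usual scatter of this kind of measurement, so the two are genuinely distinct on this read-out. Going by the values given here, no pair of measured compounds differs in only one place, so no single-change step is available to guide the next comparison.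

Compound 3, `CCCCCCCCCCCCCCCCc1nc(N(C)C)c(C)c(C)c1O`, is the next compound to be measured. It is derived from compound 1 by one change: dimethylamino in place of azetidin-1-yl on an aromatic carbon. The group that leaves and the group that enters are both small nitrogen-bearing substituents with the same count of hydrogen-bond donors and acceptors and no net charge.

Among the compounds with values here, with no measured step to lean on, the step from compound 1 to compound 3 is expected to be small, most likely within the scatter and of no clear direction. Compound 3 is therefore estimated at 80%, in a range from 65% to 92%. That corresponds to an expected step of a number 2 percentage points lower from compound 1 to compound 3 (within the scatter).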

Compound 3, a percentage reported as activity, at one concentration (the size of the read-out at that concentration, not a potency): 78%
Beside the measured number, compound 3's estimate is 2 percentage points above it; measured number inside the range.
By their numbers in this assay, from the lowest: compounds 3 and 1 (each within the scatter of the next); then compound 2.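

In this assay, replacing azetidin-1-yl with dimethylamino gives a step of a number 4 percentage points lower from compound 1 to compound 3 (within the scatter). For the compounds shown here, this is the first single-change comparison, and it shows that the two groups cannot be told apart on this read-out when placed on this aromatic carbon, next to the ring nitrogen and para to a hydroxy group. The four-membered ring is therefore not needed at this place to keep the read-out at this level at the one concentration tested, although no information on the reason for this is available.

On these data alone, the two compounds cover only a narrow choice of nitrogen substituents, so it remains open whether a bare amino group, pyrrolidin-1-yl, morpholin-4-yl or diethylamino at the same place would give a similar read-out or a clearly different one. Also open, as far as these compounds go, is whether dimethylamino could stand in for azetidin-1-yl in the same way on the core of compound 2, and whether a step this small would persist at other concentrations.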